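This account rests on a few compounds, and the source may have more. Where it says the series, first, only, none or still open, it means among the compounds named here.

In a physicochemical assay for lipophilicity, measured as octanol-water partition (a lower number here means a more polar compound, a higher number a more lipophilic compound), compound 1 `CC1=C(C(=O)OCc2cccnc2)C(c2ccc(C#N)cc2)C2=C(CCCC2=O)N1` gives 1.36, compound 2 `CC1=C(C(=O)OCc2cccnc2)C(c2cccc(O)c2)C2=C(CCCC2=O)N1` gives 1.21, and compound 3 `CC1=C(C(=O)OCc2ccccn2)C(c2ccc(C#N)cc2)C2=C(CCCC2=O)N1` gives 1.73. Compound 3 therefore holds the highest of the three numbers. Compound 4 `CC1=C(C(=O)OCc2ccccn2)C(c2cccs2)C2=C(CCCC2=O)N1` has not yet been measured. It differs from compound 3 by carrying thiophen-2-yl in place of 4-cyanophenyl on a saturated ring carbon.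

Two measured steps offer some guidance. The more relevant one changes the same saturated ring carbon: a number 0.15 log units lower from compound 1 to compound 2 (within the scatter). It stays within the scatter, although the group it brings in is 3-hydroxyphenyl, not thiophen-2-yl. The other step, a number 0.37 log units higher from compound 1 to compound 3 (beyond the scatter), is modest and goes beyond the scatter, but it puts pyridin-2-yl in place of pyridin-3-yl on a saturated chain carbon bound to an oxygen next to a carbonyl group. It therefore says little about the ring carbon that changes here. Among the measured compounds shown here, no measured compound carries thiophen-2-yl, so this guidance is thin. The expectation is a step no larger than the scatter, with only a slight, uncertain lean upward. The expected change in this assay is a number 0.17 log units higher from compound 3 to compound 4 (within the scatter). For compound 4 the estimate is 1.9, with an expected range from 1.5 to 2.3.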

Compound 4, partition coefficient: 1.77
Compound 4: the middle estimate sits 0.13 log units above what was measured; the measured number falls inside the stated range.
By their numbers in this assay, from the lowest: compounds 2 and 1 (each within the scatter of the next); then compounds 3 and 4 (each within the scatter of the next).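

In this assay the exchange of 4-cyanophenyl for thiophen-2-yl on the saturated ring carbon amounts to a number 0.04 log units higher from compound 3 to compound 4 (within the scatter) and so leaves compound 3 and compound 4 indistinguishable, even though the entering ring is five-membered, holds sulfur, and has fewer heavy atoms and no triple bond. The earlier step at this carbon, a number 0.15 log units lower from compound 1 to compound 2 (within the scatter) in the same assay, also stayed within the scatter, so both exchanges of the aromatic group seen here, made with two different pyridinyl groups in the ester, are too small to read, and neither goes against this pattern among these four compounds. Nothing available explains why this position gave such small steps.

The compounds shown leave open whether a very different group on this ring carbon, such as a carboxylic acid, an amine or a saturated cyclohexyl ring, would also stay within the scatter. They also leave open whether thiophen-2-yl would behave the same way alongside the pyridin-3-yl ester of compound 1, the setting in which the step at the ester was read.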